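Microsomal stability notes on the sulfonyl benzylamide series

A few compounds are considered here, and "the series" means these few. Any claim that something is new, unique, unknown or untested is made for them only; others in the source may bear on it.

Measured so far in an ADME assay on microsomes from liver (Homo sapiens) for metabolic stability, read by LC-MS, with a stated time of 30 min, tested at 1 uM; on this read-out lower numbers stand for a less stable compound and higher numbers for a more stable compound:
compound 1 `Cc1ccccc1S(=O)(=O)c1ccc(CNC(=O)c2cc3cnccc3[nH]2)cc1`: 48%
compound 2 `O=C(NCc1ccc(S(=O)(=O)c2ccccc2)cc1)c1cc2ncccc2s1`: 81%
compound 3 `Cn1c(C(=O)NCc2ccc(S(=O)(=O)c3ccccc3)cc2)cc2ccncc21`: 71%

Compound 2 gives the highest of the three numbers in this assay. The nearest value is that of compound 3, and the gap between these two lies within the scatter, so no order between compound 2 and compound 3 can be read from the data. The furthest value is that of compound 1, whose number lies beyond the scatter below that of compound 2.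

The next compound in the series, compound 4 `O=C(NCc1ccc(S(=O)(=O)c2ccccc2)cc1)c1cnc2nccn2c1`, has not yet been measured in this assay. Relative to compound 2 the change is a group of 9 heavy atoms (6 carbon, 3 nitrogen; one five-membered aromatic ring with 2 hetero atoms, one six-membered aromatic ring with 2 hetero atoms) in place of a group of 9 heavy atoms (7 carbon, 1 nitrogen, 1 sulfur; one five-membered aromatic ring with 1 hetero atom, one six-membered aromatic ring with 1 hetero atom), on a carbonyl carbon. Going by the values given here, no step between measured compounds matches this change, so the expectation rests only on the three values above and on the change itself.

The three measured compounds span a wide range with different ring systems on the carbonyl carbon, and for compound 4 a modest fall, not clearly beyond the scatter, is expected, an estimated step of a number 13 percentage points lower from compound 2 to compound 4 (beyond the scatter). In this assay compound 4 is thus estimated at 68%, with a range from 42% to 90%.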

Compound 4, percent of the compound remaining: 60%
Estimate against measurement, compound 4: 8 percentage points above; the range from low to high includes it.
By their numbers in this assay, from the lowest: compound 1; then compound 4; then compounds 3 and 2 (each within the scatter of the next).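

Working notes on the carbonyl position: this is the first step in the series that can be read at one place, and in this assay the exchange of ring groups on a carbonyl carbon gives a number 21 percentage points lower from compound 2 to compound 4 (beyond the scatter) in the read-out. The position is therefore not indifferent to which bicyclic group it carries, since two groups of 9 heavy atoms, each with one five-membered and one six-membered aromatic ring and neither with a hydrogen-bond donor, are not interchangeable here; the entering group has 3 nitrogen and no sulfur, and 3 hydrogen-bond acceptors in place of 2. No measurement at hand bears on what lies behind this step.

The compounds shown leave open which part of the exchange carries the step, the loss of the sulfur or the gain of nitrogen, as both change together in this one pair. Also open, as far as these compounds go, is how the read-out responds to a different kind of group on the same carbonyl carbon, such as an open-chain amine, or to a carboxylic acid or methoxy group carried on the entering ring.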